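Isobutyl on the ring carbon of the hydantoin-type core

The compounds below may be only part of what the source reports. "The series", "measured", "known", "first", "only" and "open" are said of these compounds alone.

Compound 2 `CCCN1CC(=O)N(Cc2ccc(C(=O)NO)cc2)C1=O` gives 53.4 nM in an assay on isolated protein for inhibition of protein deacetylase HDAC6 (Homo sapiens), read by fluorescence, with stated times of 10 min and 2 h (on this read-out lower numbers stand for stronger inhibition and higher numbers for weaker inhibition), the second highest of the three numbers measured. Compound 1 `CN1CC(=O)N(Cc2ccc(C(=O)NO)cc2)C1=O` gives 119 nM and compound 3 `COc1ccc(CN2CC(=O)N(Cc3ccc(C(=O)NO)cc3)C2=O)cc1` gives 28.2 nM. The step of a 2.2-fold lower number from compound 1 to compound 2 (0.35 log units; beyond the scatter) lies beyond the scatter, a 1.9-fold lower number from compound 2 to compound 3 (0.28 log units; within the scatter) lies within it, and a 4.2-fold lower number from compound 1 to compound 3 (0.63 log units; beyond the scatter) is the widest of the three. Compound 4 `CCCN1C(=O)N(Cc2ccc(C(=O)NO)cc2)C(=O)C1CC(C)C` differs from compound 2 by isobutyl in place of hydrogen on a saturated ring carbon. Going by the values given here, every measured step changes only the chain on the amide-type nitrogen; none touches a saturated ring carbon, so no step bears directly on this change. The expected step is a 1.1-fold lower number from compound 2 to compound 4 (0.03 log units; within the scatter), none beyond the scatter. Compound 4 is therefore estimated at 50 nM, within 18 nM to 140 nM.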

Compound 4, half-maximal inhibitory concentration: 174 nM
Beside the measured number, compound 4's estimate is 3.5-fold (0.54 log units) below it; measured number outside the range, above it.
By their numbers in this assay, from the lowest: compounds 3 and 2 (each within the scatter of the next); then compounds 1 and 4 (each within the scatter of the next).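

In this assay, going by these compounds alone, isobutyl in place of hydrogen on a saturated ring carbon gives a 3.3-fold higher number from compound 2 to compound 4 (0.51 log units; beyond the scatter), the first reading at this position and a step beyond the scatter. Its direction runs opposite to a 2.2-fold lower number from compound 1 to compound 2 (0.35 log units; beyond the scatter), where the change lies on the chain at the amide-type nitrogen, so that earlier trend does not carry over to the ring carbon. No supporting evidence accounts for this rise in the number.

Open, from the compounds shown here alone, is whether methyl, or a chain bearing an amine or a carboxylic acid, on this ring carbon moves the number the same way. Also open, going by these compounds, is whether isobutyl gives a similar step with 4-methoxyphenyl in place of propyl.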